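The source may report more compounds than this note shows. Statements on the series, on what has been measured and on what is new or still open speak of the compounds shown alone.

Measured so far in a functional assay on HepG2 cells (Homo sapiens) for antiproliferative activity, read by MTT assay, with a stated time of 72 h; on this read-out higher numbers stand for weaker inhibition and lower numbers for stronger inhibition:
- compound 1 `CC(C)N1C(=O)COc2ccc(-c3cnc(Cl)c(NS(=O)(=O)c4ccc(F)cc4)c3)cc21` gives 21500 nM
- compound 2 `COc1ncc(-c2ccc3c(c2)N(c2ccccc2)C(=O)CO3)cc1NS(=O)(=O)c1ccc(F)cc1` gives 14000 nM
- compound 3 `COc1ccc(N2C(=O)COc3ccc(-c4cnc(OC)c(NS(=O)(=O)c5ccc(F)cc5)c4)cc32)cc1` gives 13100 nM

Compound 3 lies within the scatter of both other compounds, so the three values do not separate in this assay. The next compound, compound 4 `COc1ncc(-c2ccc3c(c2)N(C(C)C)C(=O)CO3)cc1NS(=O)(=O)c1ccc(F)cc1`, has isopropyl in place of 4-methoxyphenyl on an amide-type nitrogen in a ring. Going by the values given here, only one measured step touches the group that leaves. This is a 1.1-fold lower number from compound 2 to compound 3 (0.03 log units; within the scatter), methoxy in place of hydrogen on an aromatic carbon, and it lies within the scatter. Among the compounds with values here, no measured step shows the aromatic ring itself being exchanged for isopropyl, so the evidence is indirect. Compound 1 already carries isopropyl on that nitrogen and gives 21500 nM, within the scatter of compound 3, although it has chloro instead of the methoxy of compound 4. With so little spread among the measured compounds, no change beyond the scatter is expected, and no direction is favoured. The estimated move is a 1.1-fold higher number from compound 3 to compound 4 (0.03 log units; within the scatter) and is expected to be no real change. For compound 4 the estimated value is 14000 nM, with an expected range from 5000 nM to 30000 nM.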

Compound 4, half-maximal inhibitory concentration: 37200 nM
Compound 4: the middle estimate sits 2.7-fold (0.42 log units) below what was measured, and the stated range ends below it.
By their numbers in this assay, from the lowest: compounds 3, 2, 1 and 4 (each within the scatter of the next, the first and the last beyond it).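

In this assay, going by these compounds alone, the exchange of an aromatic ring for isopropyl on the amide-type nitrogen is the first change at this position to go beyond the scatter, and it does so with both aromatic groups: with 4-methoxyphenyl leaving (a 2.8-fold higher number from compound 3 to compound 4 (0.45 log units; beyond the scatter)) and with phenyl leaving (a 2.7-fold higher number from compound 2 to compound 4 (0.42 log units; beyond the scatter)). The two steps are modest and point the same way, whereas methoxy on the phenyl ring itself made no real difference (a 1.1-fold lower number from compound 2 to compound 3 (0.03 log units; within the scatter)), and with isopropyl held on the nitrogen, methoxy in place of chloro on an aromatic carbon also stays within the scatter (a 1.7-fold higher number from compound 1 to compound 4 (0.24 log units; within the scatter)). Nothing available here explains why the aromatic groups and isopropyl differ in this way.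

The compounds shown leave open whether this difference belongs to aromatic rings in general, since phenyl and 4-methoxyphenyl alone represent them and isopropyl alone represents the groups without a ring. From the compounds shown here alone, how a cyclohexyl ring, a benzyl group or a longer chain ending in an amine would read on that nitrogen also stays open, as does whether the step would hold with chloro in place of the methoxy.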